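A few compounds are considered here, and "the series" means these few. Any claim that something is new, unique, unknown or untested is made for them only; others in the source may bear on it.

Two measured compounds set the frame for this series. Compound 1, `CC[C@@H]1C(=O)N(C)c2cnc(-n3ccc4cc(C(N)=O)ccc43)nc2N1C1CCCC1`, is the higher of the two numbers in an assay for inhibition of serine/threonine-protein kinase PLK2 (Homo sapiens), read by FRET and Z'-LYTE, with a stated time of 1 h (a higher number here means a weaker inhibitor, a lower number a stronger inhibitor), where compound 1 gives 28.5 nM. Its nearest neighbour is compound 2, `CC[C@@H]1C(=O)N(C)c2cnc(Nc3ccc(S(=O)(=O)NCCCO)cc3)nc2N1C1CCCC1`, a compound that carries a different substituent on the shared core; in this assay compound 2 gives 8.16 nM, a number lower than that of compound 1 by a margin that lies beyond the usual scatter. For the measured compounds named here, no pair of measured compounds differing in one place is available, so no single step has been quantified.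

The next compound to consider is compound 3, `CCNC(=O)c1ccc2c(ccn2-c2ncc3c(n2)N(C2CCCC2)[C@H](CC)C(=O)N3C)c1`. Relative to compound 1, compound 3 shows the following difference: ethyl in place of hydrogen on an amide-type nitrogen. The amino group of the carbamoyl becomes an ethylamino group; the rest of the structure is kept.

Going by the values given here, with no measured step to lean on, the step from compound 1 to compound 3 is expected to be modest, most likely no more than a small shift toward a higher number, and possibly none beyond the scatter, giving an expected 1.4-fold higher number from compound 1 to compound 3 (0.15 log units; within the scatter). For compound 3 the estimate in this assay is 40 nM, within a range from 15 nM to 110 nM.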

Compound 3, half-maximal inhibitory concentration: 4.88 nM
Beside the measured number, compound 3's estimate is 8.2-fold (0.91 log units) above it; the whole stated range lies above it.
By their numbers in this assay, from the lowest: compounds 3 and 2 (each within the scatter of the next); then compound 1.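

Ethyl in place of hydrogen on the amide-type nitrogen gives the first quantified single step in this series: in this assay, the change produces a 5.8-fold lower number from compound 1 to compound 3 (0.77 log units; beyond the scatter), a shift toward a stronger inhibitor. This position is therefore responsive to substitution, and amino to ethylamino on the carbamoyl is a productive change on the core of compound 1, with the remaining amide hydrogen kept and the rest of the structure unchanged. No measurement here bears on why the step runs in this direction or has this size.

Going by these compounds, a single substituent at a single position defines neither a trend nor a limit: whether a longer chain such as propyl, a branched chain such as isopropyl, a ring such as cyclopropyl, or an ethyl chain ending in a hydroxyl or an amine would extend, keep or reverse the step remains open. Also open, on these data alone, is whether a second substituent on the same nitrogen, as in dimethylcarbamoyl, would be accepted, and whether the step from ethyl holds when the cyclopentyl or the ring-carbon ethyl group of the shared core is changed.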